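Swapping the aryl ring on the enone chain of compound 1

The source may report more compounds than this note shows. Statements on the series, on what has been measured and on what is new or still open speak of the compounds shown alone.

Compound 1 `Cc1cc(C)cc(/C=C(\C(=O)c2ccc(Cl)cc2)S(=O)(=O)c2ccc(Br)cc2)c1` was tested in a functional assay on DU-145 cells (Homo sapiens) for inhibition, read by trypan blue exclusion, with a stated time of 96 h (a lower number here means a stronger inhibitor of growth, a higher number a weaker inhibitor of growth), where compound 1 gives 10000 nM. That is the highest of the three numbers recorded. Compound 2 `Cc1cc(C)cc(/C=C(\C(=O)c2ccc(Cl)cc2)S(=O)(=O)Cc2ccc(Cl)cc2)c1` gives 1000 nM in this assay, and compound 3 `O=C(/C(=C\c1c[nH]c2ccc(Cl)cc12)SCc1ccc(F)cc1)c1ccc(Br)cc1` gives 1000 nM. Among the measured compounds shown here, the single step measured between compounds differing in one place is a 10-fold lower number from compound 1 to compound 2 (1.00 log units; beyond the scatter), a change on the sulfonyl sulfur, not on the aryl ring attached to the chain.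

Compound 4 `O=C(/C(=C\c1c(O)cc(O)cc1O)S(=O)(=O)c1ccc(Br)cc1)c1ccc(Cl)cc1` has not yet been measured in this assay. It differs from compound 1 as follows: 2,4,6-trihydroxyphenyl in place of 3,5-dimethylphenyl on a double-bonded chain carbon bound to a double-bonded chain carbon. For the measured compounds named here, no measured step concerns this position, so the step from compound 1 to compound 2 offers only indirect guidance: it shows that a single change elsewhere in this core can move the number well beyond the scatter. The values of compound 2 and compound 3 show that the core can reach lower numbers than compound 1.

Compound 4 is therefore expected to show a step of a 2.5-fold lower number from compound 1 to compound 4 (0.40 log units; beyond the scatter), with low confidence in its direction. Compound 4 is estimated at 4000 nM, within the range 700 nM to 20000 nM.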

Compound 4, concentration for 50% growth inhibition: > 100000 nM
Compound 4 ended at the assay's limit; the forecaster's own chance of this, stated with the estimate: 15%; middle value at least 25-fold (1.39 log units) away from the limit.
By their numbers in this assay, from the lowest: compounds 2 and 3 (each within the scatter of the next); then compound 1. At a limit, above all of these: compound 4.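

In this assay, the position on a double-bonded chain carbon bound to a double-bonded chain carbon is shown to matter: with 2,4,6-trihydroxyphenyl in place of 3,5-dimethylphenyl, the step is an at least 10-fold higher number from compound 1 to compound 4 (1.00 log units; beyond the scatter). Among the compounds shown here, the only earlier step, a 10-fold lower number from compound 1 to compound 2 (1.00 log units; beyond the scatter), lay on the sulfonyl sulfur and went to a lower number, so this is the first sign that a single change to the core of compound 1 can also move the number upward, here with the six-membered aromatic ring kept and hydrogen-bond donors and acceptors entering where the leaving group had none. The value of compound 4 is a limit and not a number: the limit of > 100000 nM in this assay, at which 1 of the 4 values shown sits.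

A single replacement at this position cannot separate the entry of the three hydroxyl groups from the loss of the two methyl groups, and the compounds shown give no cause for the step. From the compounds shown here alone, how a phenyl ring carrying one hydroxyl, methoxy groups or an amine would read here stays open, as does whether the same replacement would act alike with the 4-chlorobenzyl group of compound 2 on the sulfonyl sulfur.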